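The source may report more compounds than this note shows. Statements on the series, on what has been measured and on what is new or still open speak of the compounds shown alone.

Four compounds share one core and differ at two spots. Compound 1 is `CCOC(=O)c1c(C)[n+]([O-])c2cc(-n3ccnc3)c(F)cc2[n+]1[O-]`. In an ADME assay on Vero cells (Chlorocebus sabaeus) for cytotoxicity, read by MTT assay, with a stated time of 72 h (a higher number here means a weaker inhibitor, a lower number a stronger inhibitor), compound 1 gives 129000 nM. Compound 2, `CCOC(=O)c1c(C)[n+]([O-])c2cc(-n3cncn3)c(F)cc2[n+]1[O-]`, differs from compound 1 in one way: 1H-1,2,4-triazol-1-yl in place of 1H-imidazol-1-yl on an aromatic carbon. In this assay compound 2 gives 155000 nM, which is a 1.2-fold higher number from compound 1 to compound 2 (0.08 log units; within the scatter). Compound 3, `CCOC(=O)c1c(C(F)(F)F)[n+]([O-])c2cc(-n3ccnc3)c(F)cc2[n+]1[O-]`, carries a different group on the core than compound 1: trifluoromethyl in place of methyl on an aromatic carbon. In this assay compound 3 gives 19400 nM, which is a 6.6-fold lower number from compound 1 to compound 3 (0.82 log units; beyond the scatter); among the three measured compounds this is the lowest number, and its gap to each of the other two lies beyond the scatter.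

Compound 4 is `CCOC(=O)c1c(C(F)(F)F)[n+]([O-])c2cc(-n3cncn3)c(F)cc2[n+]1[O-]`. It stands to compound 3 as compound 2 stands to compound 1, with 1H-1,2,4-triazol-1-yl in place of 1H-imidazol-1-yl on an aromatic carbon. The change is the same one, at the same place, with the same surroundings; only the core differs, in the way described above for compound 3 against compound 1. Because the same change gave a 1.2-fold higher number from compound 1 to compound 2 (0.08 log units; within the scatter), compound 4 is expected to show a 1.1-fold higher number from compound 3 to compound 4 (0.05 log units; within the scatter) in this assay, a step within the scatter. Compound 4 is therefore estimated at 22000 nM, with a likely range from 11000 nM to 45000 nM. This expectation rests on a single earlier example of the change, so the range is kept wide.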

Compound 4, half-maximal inhibitory concentration: 35400 nM
Compound 4: middle estimate off by 1.6-fold (0.21 log units), on the low side; low and high end bracket the measured number.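

In this assay, putting 1H-1,2,4-triazol-1-yl in place of 1H-imidazol-1-yl on the trifluoromethyl core gives a 1.8-fold higher number from compound 3 to compound 4 (0.26 log units; within the scatter), and this step agrees with the same change on the methyl core: the same change on two cores in this assay, a 1.2-fold higher number (0.08 log units; within the scatter) from compound 1 to compound 2 and a 1.8-fold higher number (0.26 log units; within the scatter) from compound 3 to compound 4, 1.5-fold (0.18 log units) apart, within the scatter of two such steps. The other change also carries over, as trifluoromethyl in place of methyl, now with 1H-1,2,4-triazol-1-yl on the ring, gives a 4.4-fold lower number from compound 2 to compound 4 (0.64 log units; beyond the scatter), a step of similar size to the one seen with 1H-imidazol-1-yl: the same change on two cores in this assay, a 6.6-fold lower number (0.82 log units; beyond the scatter) from compound 1 to compound 3 and a 4.4-fold lower number (0.64 log units; beyond the scatter) from compound 2 to compound 4, 1.5-fold (0.18 log units) apart, within the scatter of two such steps. Together these four compounds show that each change had much the same effect in both settings tested, but each comparison rests on just two pairs, so they do not show that either change would carry over to other cores or to other assays, and they do not explain why the numbers behave this way.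

The compounds shown leave open how the numbers in this assay would respond to other groups in place of the methyl or trifluoromethyl group, such as a longer chain or an amine. They also leave open what would happen if the ethyl ester gave way to a carboxylic acid, or if a ring other than these two stood in place of 1H-imidazol-1-yl.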